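Trimming a Hydroxyl-Bearing Side Chain on a Kinase Inhibitor

A few compounds are considered here, and "the series" means these few. Any claim that something is new, unique, unknown or untested is made for them only; others in the source may bear on it.

Compound 1 `C[C@@H](O)CNc1cc(Oc2ccc(NC(=O)Nc3cccc(C(F)(F)F)c3)cc2)ncn1` gives 63 nM in an assay on isolated protein for inhibition of serine/threonine-protein kinase TNNI3K (Homo sapiens); a higher number here means a weaker inhibitor, a lower number a stronger inhibitor. Going by the values given here, of the two compounds measured so far, compound 1 has the lowest number; the other, compound 2 `CCc1cccc(NC(=O)Nc2ccc(Oc3cc(NC)ncn3)cc2)c1`, gives 200 nM in this assay, a gap beyond the usual scatter. Compound 2 differs from compound 1 in more than one place, so its value alone does not show which change matters.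

Compound 3 `CCNc1cc(Oc2ccc(NC(=O)Nc3cccc(C(F)(F)F)c3)cc2)ncn1` has not yet been measured. It differs from compound 1 in a single spot: methyl in place of 1-hydroxyethyl on a saturated chain carbon bound to a nitrogen on an aromatic ring. The side chain loses its hydroxyl group and becomes shorter, while the rest of the molecule, including the urea and the trifluoromethyl-bearing ring, stays the same. Among the compounds with values here, no measured pair isolates this change. The expectation is a small step toward a weaker inhibitor, a 1.6-fold higher number from compound 1 to compound 3 (0.20 log units; within the scatter), though possibly none beyond the scatter. Compound 3 is therefore estimated at 100 nM, within a range from 40 nM to 250 nM.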

Compound 3, half-maximal inhibitory concentration: 25 nM
Beside the measured number, compound 3's estimate is 4.0-fold (0.60 log units) above it; the measured number lies below the stated range.
By their numbers in this assay, from the lowest: compound 3; then compound 1; then compound 2.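

In this assay, replacing 1-hydroxyethyl with methyl gives a 2.5-fold lower number from compound 1 to compound 3 (0.40 log units; beyond the scatter), a modest step toward a stronger inhibitor. Going by these compounds alone, this is the first single-place comparison at this position, and it shows that the side chain's hydroxyl group and defined stereocentre are not required for activity here: the shorter ethylamino form does better than the (2-hydroxypropyl)amino form. Nothing shown here explains why the number falls.

This single step changes the chain's length and removes the hydroxyl group together, so the compounds shown cannot tell which of the two matters. A plain propyl chain would help separate these two changes, while a longer alkyl chain or a chain ending in an amine would show how far this position tolerates other groups.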